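Aryl sulfonyl in place of allylcarbamoyl on the ring nitrogen

A few compounds are considered here, and "the series" means these few. Any claim that something is new, unique, unknown or untested is made for them only; others in the source may bear on it.

Measured so far:
compound 1 `C=CCNC(=O)n1c(-c2ccc(OC)cc2)cc(=O)c2c(OC)cc(OC)cc21` — > 20000 nM
compound 2 `COc1ccc(-c2c(Br)c(=O)c3c(OC)cc(OC)cc3n2S(=O)(=O)c2ccc(OC)cc2)cc1` — > 20000 nM
compound 3 `COC(=O)c1cc(=O)c2cc(N)ccc2[nH]1` — > 33700 nM

In a functional assay on HepG2 cells (Homo sapiens) for antiproliferative activity, with a stated time of 72 h (on this read-out higher numbers stand for an effect only at larger amounts of compound and lower numbers for an effect already at smaller amounts), compound 1 gives only a limit, > 20000 nM. Compound 2 likewise sits at a limit, > 20000 nM, as noted in the limit of > 20000 nM in this assay, at which 2 of the 3 values shown sit. Compound 3 is a limit as well, > 33700 nM, per (the limit of > 33700 nM in this assay, at which 1 of the 3 values shown sits). Within the data shown here, no step between two measured compounds is available, so nothing measured tells how a change on the aromatic nitrogen moves the read-out.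

Compound 4 `COc1ccc(-c2cc(=O)c3c(OC)cc(OC)cc3n2S(=O)(=O)c2ccc(Cl)cc2)cc1` is not yet measured. It differs from compound 1 in one place: (4-chlorophenyl)sulfonyl in place of allylcarbamoyl on an aromatic nitrogen. The closest measured relative, compound 2, also carries a sulfonyl on that nitrogen and stays at its limit. The step from compound 1 to compound 4 in this assay is therefore expected to be none beyond the usual scatter, a step that the limit leaves unreadable from compound 1 to compound 4. Compound 4 is expected at 30000 nM, within 8000 nM to 100000 nM, most likely reported as a limit.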

Compound 4, half-maximal effective concentration: > 34400 nM
Compound 4: no number, only a limit; the forecaster's own chance of this, stated with the estimate: 75%; middle value at least 1.1-fold (0.05 log units) from the limit.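

Among these compounds, compound 1 and compound 4 both stand only as limits in this assay, so no step between them can be read. The compounds shown leave open whether any group on that aromatic nitrogen gives a measurable number in this assay.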